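The source may report more compounds than this note shows. Statements on the series, on what has been measured and on what is new or still open speak of the compounds shown alone.

Compound 1 `COc1ccc2c(=O)c(-c3ccc(Oc4ccc(OC(F)(F)F)cc4)cc3)c(C)[nH]c2c1` gives > 10000 nM in an ADME assay on HepG2 cells (Homo sapiens) for cytotoxicity, read by resazurin assay, with a stated time of 24 h (a higher number here means a weaker inhibitor, a lower number a stronger inhibitor), a limit of the assay rather than a number. Compound 2 `Cc1[nH]c2ccccc2c(=O)c1-c1ccc(Oc2ccc(OC(F)(F)F)cc2)cc1` gives > 10000 nM in this assay, again only a limit. Compound 3 `Cc1[nH]c2ccc(Cl)cc2c(=O)c1-c1ccc(Oc2ccc(OC(F)(F)F)cc2)nc1` gives > 10000 nM in this assay, likewise a limit.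

All three measured values thus sit at the limit of > 10000 nM in this assay, at which 3 of the 3 values shown sit. The change from compound 2 to compound 1, (methoxy in place of hydrogen on an aromatic carbon), gives a step that the two limits leave unreadable from compound 2 to compound 1. How the core of compound 3 differs from the core of compound 2 is not broken down here.

Compound 4 `COc1cc2[nH]c(C)c(-c3ccc(Oc4ccc(OC(F)(F)F)cc4)nc3)c(=O)c2cc1Cl` has not yet been measured in this assay. It arises from compound 3 by methoxy in place of hydrogen on an aromatic carbon, the same kind of change as that from compound 2 to compound 1, though here the entering methoxy stands ortho to a chloro group, which the earlier pair lacks. Because compound 3 sits at > 10000 nM, and because the earlier pair shows a step that the two limits leave unreadable from compound 2 to compound 1, the expected step is a step that the limit leaves unreadable from compound 3 to compound 4. Compound 4 is therefore estimated at 15000 nM, between 7000 nM and 40000 nM, most probably reported once more as a limit only.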

Compound 4, half-maximal inhibitory concentration: > 10000 nM
Compound 4 ended at the assay's limit; the forecaster's own chance of this, stated with the estimate: 85%; the middle value lies beyond the limit too.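

The step from compound 3 to compound 4 cannot be read, since both compounds give only a limit in this assay, so this result adds no new step: the limit of > 10000 nM in this assay, at which 4 of the 4 values shown sit.

The compounds shown leave open whether methoxy in place of hydrogen on an aromatic carbon changes the read-out at all, and what concentration any of these four compounds would need to reach half-maximal inhibition.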